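The compounds below may be only part of what the source reports. "The series", "measured", "known", "first", "only" and "open" are said of these compounds alone.

Compound 1 `Nc1nc(N)c(CCCN(Cc2ccc(NC(CCC(=O)O)C(=O)O)cc2)c2cc(F)c([N+](=O)[O-])cc2[N+](=O)[O-])c(O)n1` and compound 2 `COC(=O)c1ccc(CN(CCCc2c(N)nc(N)nc2O)c2cc(F)c([N+](=O)[O-])cc2[N+](=O)[O-])cc1` share one core and differ in a single place. In a functional assay on CCRF-CEM cells (Homo sapiens) for cytotoxicity, in the absence of a further agent (on this read-out lower numbers stand for stronger inhibition and higher numbers for weaker inhibition), compound 1 gives 51000 nM, while compound 2 gives 4300 nM; this is a 12-fold lower number from compound 1 to compound 2 (1.07 log units; beyond the scatter), brought about by the change (methoxycarbonyl in place of (1,3-dicarboxypropyl)amino on an aromatic carbon). Compound 3 `Nc1nc(N)c(CCCN(Cc2ccc(NC(CCC(=O)O)C(=O)O)cc2)c2ccc([N+](=O)[O-])c(F)c2F)c(O)n1` carries a different core, and the difference between the two cores is not broken down here. In this assay compound 3 reaches only a limit, > 100000 nM, which is the limit of > 100000 nM in this assay, at which 1 of the 3 values shown sits. Compound 4 `COC(=O)c1ccc(CN(CCCc2c(N)nc(N)nc2O)c2ccc([N+](=O)[O-])c(F)c2F)cc1` arises from compound 3 through (methoxycarbonyl in place of (1,3-dicarboxypropyl)amino on an aromatic carbon), the same change as before at the same kind of place. A step of roughly the size seen in a 12-fold lower number from compound 1 to compound 2 (1.07 log units; beyond the scatter) is expected, so compound 4 is estimated at 15000 nM in this assay, a step of an at least 6.6-fold lower number from compound 3 to compound 4 (0.82 log units; beyond the scatter), with a range from 4000 nM to 80000 nM.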

Compound 4, half-maximal inhibitory concentration: 55000 nM
Compound 4: the middle estimate sits 3.7-fold (0.56 log units) below what was measured, and the stated range covers the measured number.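

In this assay, putting methoxycarbonyl in place of (1,3-dicarboxypropyl)amino on the core of compound 3 gives an at least 1.8-fold lower number from compound 3 to compound 4 (0.25 log units; that floor lies within the scatter), and that floor alone does not rise beyond the usual scatter. Compound 3 has only a limit, > 100000 nM, not a true number. The result therefore does not go against a lower number on this core, but it does not show that the size of the step carries over from the core of compound 1: the same change on two cores in this assay, a 12-fold lower number (1.07 log units; beyond the scatter) from compound 1 to compound 2 and an at least 1.8-fold lower number (0.25 log units; that floor lies within the scatter) from compound 3 to compound 4; the limit leaves it open whether they differ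

The compounds shown leave open what a carboxylic acid or an amide would give in place of methoxycarbonyl on that aromatic carbon. They also leave open whether a smaller amine there would give a step like that of methoxycarbonyl on either core.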